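The source may hold more compounds than are shown below. What is called first, only, known or untested is meant among the compounds shown, and "the series" means these compounds.

In a functional assay on 143B cells (Homo sapiens) for inhibition, read by MTT assay, with a stated time of 72 h (on this read-out higher numbers stand for weaker inhibition and lower numbers for stronger inhibition), three compounds sharing one core and differing in the group on an amide-type nitrogen give very similar numbers: compound 1 `O=C(CCC(=O)OCCCCCCSc1ccc([N+](=O)[O-])c2nonc12)Nc1ccccc1F` gives 3030 nM, compound 2 `O=C(CCC(=O)OCCCCCCSc1ccc([N+](=O)[O-])c2nonc12)Nc1ccccc1Cl` gives 2430 nM, and compound 3 `O=C(CCC(=O)OCCCCCCSc1ccc([N+](=O)[O-])c2nonc12)Nc1ccc(Br)cc1` gives 2710 nM. Compound 2 therefore sits level with the other two, within the scatter of repeated measurements.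

Compound 4 `Cc1ccc(NC(=O)CCC(=O)OCCCCCCSc2ccc([N+](=O)[O-])c3nonc23)cc1` comes from compound 2 by a single change: 4-methylphenyl in place of 2-chlorophenyl on an amide-type nitrogen. The closest measured parallel is the replacement of 2-chlorophenyl by 4-bromophenyl at the same place, which gave a 1.1-fold higher number from compound 2 to compound 3 (0.05 log units; within the scatter). The other two swaps there gave a 1.2-fold lower number from compound 1 to compound 2 (0.10 log units; within the scatter) and a 1.1-fold lower number from compound 1 to compound 3 (0.05 log units; within the scatter). All three steps are too small to count as real differences. Among the measured compounds shown here, none of the measured compounds carries 4-methylphenyl, so this group is untested, but the steps so far give no reason to expect a shift beyond the scatter in this assay. The expected change is a 1.1-fold higher number from compound 2 to compound 4 (0.05 log units; within the scatter). For compound 4, the estimated value is 2700 nM, with an expected range of 1500 nM to 4800 nM.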

Compound 4, half-maximal inhibitory concentration: 3250 nM
Compound 4: the middle estimate sits 1.2-fold (0.08 log units) below what was measured; measured number inside the range.
By their numbers in this assay, from the lowest: compounds 2, 3, 1 and 4 (each within the scatter of the next).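

Among the compounds shown here, on this amide-type nitrogen, 4-methylphenyl is the first group here with no halogen on its ring, yet the read-out in this assay stays put: the change gives a 1.3-fold higher number from compound 2 to compound 4 (0.13 log units; within the scatter) and a 1.2-fold higher number from compound 3 to compound 4 (0.08 log units; within the scatter) as well as a 1.1-fold higher number from compound 1 to compound 4 (0.03 log units; within the scatter) and none of these counts as a real difference. Across these four compounds, then, a halogen on this ring is not needed to keep the number, and methyl takes the place of bromo with no readable effect. Nothing measured here explains why these groups behave alike.

Going by these compounds, all four compounds carry a phenyl ring with one small group on it, so it remains open whether an amine or a carboxylic acid on that ring, or a cyclohexyl group in its place, would shift the number. These compounds also cannot tell how much of the number comes from the shared core rather than from this end of the molecule.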